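Thiosemicarbazone series: removing trifluoromethyl from compound 2

This account rests on a few compounds, and the source may have more. Where it says the series, first, only, none or still open, it means among the compounds named here.

Three thiosemicarbazones have been run in a functional assay on SGC-7901 cells (Homo sapiens) for antiproliferative activity, read by sulforhodamine B assay, with a stated time of 72 h; on this read-out lower numbers stand for stronger inhibition and higher numbers for weaker inhibition. Compound 1 `CN(C)C(=S)N/N=C/c1cc2cccnc2s1` gives 21400 nM in this assay; compound 2 `FC(F)(F)c1ccccc1NC(=S)N/N=C/c1ccc2ccccc2n1` gives 20700 nM; compound 3 `CN(C)C(=S)N/N=C/c1nc2ccccc2s1` gives 830 nM. Compound 2 stands second highest of the three numbers, with compound 1 within the scatter of it and compound 3 well beyond it on the lower side. Compound 4 `S=C(N/N=C/c1ccc2ccccc2n1)Nc1ccccc1` differs from compound 2 in one place: hydrogen in place of trifluoromethyl on an aromatic carbon. Within the data shown here, no measured pair tracks this change, so its size is unknown here. In this assay the step from compound 2 to compound 4 is expected to stay within the scatter, with at most a slight move toward a lower number. Compound 4 is estimated at 15000 nM, in the range 5000 nM to 40000 nM. The expected step of a 1.4-fold lower number from compound 2 to compound 4 (0.14 log units; within the scatter) is small.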

Compound 4, half-maximal inhibitory concentration: 26500 nM
Beside the measured number, compound 4's estimate is 1.8-fold (0.25 log units) below it, within the range that was stated.
By their numbers in this assay, from the lowest: compound 3; then compounds 2, 1 and 4 (each within the scatter of the next).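

In this assay, among these compounds, hydrogen in place of trifluoromethyl on an aromatic carbon, ortho to a large group, gives a 1.3-fold higher number from compound 2 to compound 4 (0.11 log units; within the scatter), the first measured step at this place. This pair therefore shows no readable dependence on trifluoromethyl here, so the group can be lost without a measurable penalty on this read-out. Nothing measured speaks to why the step is this small.

Going by these compounds, whether an amine or a carboxylic acid at this place would also stay within the scatter of compound 4 remains open. So does whether the same swap would read alike on the core of compound 3.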